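The source may report more compounds than this note shows. Statements on the series, on what has been measured and on what is new or still open speak of the compounds shown alone.

Compound 1 `CCN(CC)S(=O)(=O)c1ccc(S(=O)(=O)N2CCC[C@@H](C(=O)N(C)C(C)C)C2)cc1` gives 1400 nM in this read-out, and compound 2 `CCN(CC)S(=O)(=O)c1ccc(S(=O)(=O)N2CCC[C@@H](C(=O)NC3CN(C(=O)OC(C)(C)C)C3)C2)cc1` gives 100 nM.

In a functional assay on MIA PaCa-2 cells (Homo sapiens) for inhibition, read by MTT assay, with a stated time of 3 days (on this read-out higher numbers stand for weaker inhibition and lower numbers for stronger inhibition), compound 1 stands with the higher of the two numbers. For the measured compounds named here, the one measured step, a 14-fold lower number from compound 1 to compound 2 (1.15 log units; beyond the scatter), comes from swapping the group on the carbonyl carbon. Compound 3 `CCN(CC)S(=O)(=O)c1ccc(S(=O)(=O)N2CCC[C@@H](c3nc(C)no3)C2)cc1` differs from compound 1 by 3-methyl-1,2,4-oxadiazol-5-yl in place of isopropyl(methyl)carbamoyl on a saturated ring carbon, so here the carbonyl itself is removed rather than the group on it. Going by the values given here, no measured step bears on that change, and the measured step is no guide to it. The step is expected to be a 1.4-fold lower number from compound 1 to compound 3 (0.15 log units; within the scatter). Compound 3 is estimated at 1000 nM, with a range from 300 nM to 4000 nM.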

Compound 3, half-maximal inhibitory concentration: 700 nM
For compound 3 the middle estimate is 1.4-fold (0.15 log units) above the measured one, within the range that was stated.
By their numbers in this assay, from the lowest: compound 2; then compounds 3 and 1 (each within the scatter of the next).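

In this assay, 3-methyl-1,2,4-oxadiazol-5-yl in place of isopropyl(methyl)carbamoyl gives a 2.0-fold lower number from compound 1 to compound 3 (0.30 log units; within the scatter) on this saturated ring carbon. The earlier step changed only the group on the carbonyl, whereas this one shows that the carbonyl can be replaced by a five-membered aromatic ring with 3 hetero atoms without a shift beyond the scatter. No evidence is available that explains this result. As far as these compounds go, it remains open how a carboxylic acid, a primary amine or a phenyl ring would read on this ring carbon.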